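Replacing 1H-pyrrol-2-yl with 2-methoxyphenyl in compound 2

This account rests on a few compounds, and the source may have more. Where it says the series, first, only, none or still open, it means among the compounds named here.

Among the measured compounds shown here, in a functional assay on P388 cells (Mus musculus) for cytotoxicity (a lower number here means a stronger inhibitor, a higher number a weaker inhibitor), compound 2 (`Cc1cc(-c2c(F)cc3c(=O)c(Cc4ccc[nH]4)cn(C4CC4)c3c2F)cc(C)n1`) gives 930 nM and holds the lower of the two numbers measured so far, while compound 1 (`Cc1cc(-c2c(F)cc3c(=O)c(Cc4cccc(O)c4)cn(C4CC4)c3c2F)cc(C)n1`) gives 2200 nM in the same test. For the measured compounds named here, the only measured step, a 2.4-fold lower number from compound 1 to compound 2 (0.37 log units; beyond the scatter), brought in 1H-pyrrol-2-yl in place of 3-hydroxyphenyl. Compound 3 (`COc1ccccc1Cc1cn(C2CC2)c2c(F)c(-c3cc(C)nc(C)c3)c(F)cc2c1=O`) now puts 2-methoxyphenyl in place of 1H-pyrrol-2-yl on a saturated chain carbon bound to an aromatic carbon, counted as 2-methoxyphenyl in place of 1H-pyrrol-2-yl on a saturated chain carbon bound to an aromatic carbon in full. Going by the values given here, it thus regains a six-membered aromatic ring of carbon only, as compound 1 has, although no measured compound carries 2-methoxyphenyl. Among the compounds with values here, the one step, a 2.4-fold lower number from compound 1 to compound 2 (0.37 log units; beyond the scatter), is therefore expected to be roughly undone in this assay, with a modest move towards a higher number. The expected step is a 2.2-fold higher number from compound 2 to compound 3 (0.33 log units; beyond the scatter) on this estimate. Compound 3 is estimated at 2000 nM with an expected range of 700 nM to 6000 nM here.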

Compound 3, half-maximal inhibitory concentration: 37000 nM
Estimate against measurement, compound 3: 19-fold (1.27 log units) below; the measured number lies above the stated range.
By their numbers in this assay, from the lowest: compound 2; then compound 1; then compound 3.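

In this assay, among the compounds shown here, the step of a 40-fold higher number from compound 2 to compound 3 (1.60 log units; beyond the scatter) shows that this place on a saturated chain carbon bound to an aromatic carbon can move the number much further than the earlier pair suggested, where the only step was a 2.4-fold lower number from compound 1 to compound 2 (0.37 log units; beyond the scatter). A six-membered aromatic ring of carbon only does not by itself set the number, since compound 1 and compound 3 both carry one and the step of a 17-fold higher number from compound 1 to compound 3 (1.23 log units; beyond the scatter) still separates them, so the group on that ring matters here. Nothing available here accounts for this rise.

Between compound 1 and compound 3, the group on the ring and its place change together, so the two cannot be told apart. Plain phenyl, 2-hydroxyphenyl or 3-methoxyphenyl at this place would separate them, and whether furan-2-yl would match 1H-pyrrol-2-yl remains open.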